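Bromo to Methyl on the Aryl Isoxazole Side Chain

The source may hold more compounds than are shown below. What is called first, only, known or untested is meant among the compounds shown, and "the series" means these compounds.

Measured compounds:
compound 1, `CCOC(=O)C1=Cc2ccccc2OC1(OCc1cc(-c2ccc(Br)cc2)no1)C(F)(F)F` — 52300 nM
compound 2, `CCOC(=O)C1=Cc2ccccc2OC1(OCc1cn(-c2ccc(F)c([N+](=O)[O-])c2)nn1)C(F)(F)F` — 15600 nM

In a functional assay on HeLa cells (Homo sapiens) for inhibition, read by MTT assay, with a stated time of 24 h (a higher number here means a weaker inhibitor, a lower number a stronger inhibitor), compound 1 gives 52300 nM, the highest of the two numbers shown. Going by the values given here, compound 2, the only other measured compound, gives 15600 nM, a lower number that lies beyond the scatter; the two structures differ in several places, so this gap alone is not a clean single step.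

Compound 3, `CCOC(=O)C1=Cc2ccccc2OC1(OCc1cc(-c2ccc(C)cc2)no1)C(F)(F)F`, has not been measured. It differs from compound 1 in one place: methyl in place of bromo on an aromatic carbon. Among the compounds with values here, no measured pair shows this same change, so the expected step rests on the weak inhibition of compound 1 at 52300 nM and the small size of the swap. For compound 3 the step of a 1.1-fold lower number from compound 1 to compound 3 (0.04 log units; within the scatter) is expected to be small, likely within the scatter, with no firm direction. Compound 3 is therefore estimated at 48000 nM, within 20000 nM to 115000 nM.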

Compound 3, half-maximal inhibitory concentration: > 150000 nM
Compound 3: no number, only a limit (the forecaster's own chance of this, stated with the estimate: 20%); middle value at least 3.1-fold (0.49 log units) from the limit.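

Going by these compounds alone, the change from 4-bromophenyl to 4-methylphenyl gives the first step between compounds that differ in one place, an at least 2.8-fold higher number from compound 1 to compound 3 (0.45 log units; beyond the scatter), so this position on the aromatic ring responds to the exchange of one heavy atom for another, even though compound 1 is already a weak inhibitor. In this assay compound 3 gives > 150000 nM, which is a limit of the assay and not a number. The step therefore has a lower end only, and its full size cannot be read: the limit of > 150000 nM in this assay, at which 1 of the 3 values shown sits.

Why bromo and methyl part here remains unexplained, and a single pair sets no trend. From the compounds shown here alone, whether chloro, a methoxy group or an amine at this place would stay nearer compound 1 or nearer compound 3 also remains open.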